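This account rests on a few compounds, and the source may have more. Where it says the series, first, only, none or still open, it means among the compounds named here.

Measured so far:
compound 1 `O=C(NO)C(Cc1ccccc1)C(=O)NCc1ccc(F)cc1` — 0.8 h
compound 2 `O=C(NO)/C(=C\c1ccccc1)C(=O)NCc1ccc(F)cc1` — 22 h
compound 3 `CN(O)C(=O)C(Cc1ccccc1)C(=O)NCc1ccc(F)cc1` — 0.5 h

In an ADME assay on a cell-free system (plasma, Rattus norvegicus, strain Sprague-Dawley) for metabolic stability, read by LC-MS, tested at 10 uM (a higher number here means that the compound lasts longer, a lower number that the compound disappears faster), compound 1 gives 0.8 h, the second highest of the three values. Compound 3 is nearest, with a 1.6-fold lower number from compound 1 to compound 3 (0.20 log units; within the scatter). Among the measured compounds shown here, compound 2 stands far higher at 22 h; no single step connects it to compound 1.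

Compound 4 `CC(C(=O)NO)C(=O)NCc1ccc(F)cc1` is not yet measured. Relative to compound 1 the change is hydrogen in place of phenyl on a saturated chain carbon, two bonds along the chain from two carbonyl carbons. For the measured compounds named here, no measured step touches this part of the core: the only step recorded, a 1.6-fold lower number from compound 1 to compound 3 (0.20 log units; within the scatter), concerns the amide-type nitrogen and stayed within the scatter, so it gives no direction for the chain carbon. With nothing pointing either way, no step beyond the scatter is expected in this assay, and compound 4 is estimated at 0.7 h (range 0.3 h to 1.8 h), i.e. a 1.1-fold lower number from compound 1 to compound 4 (0.06 log units; within the scatter).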

Compound 4, half-life: 33 h
Estimate against measurement, compound 4: 47-fold (1.67 log units) below; measured number outside the range, above it.
By their numbers in this assay, from the lowest: compounds 3 and 1 (each within the scatter of the next); then compounds 2 and 4 (each within the scatter of the next).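

Hydrogen in place of phenyl on a saturated chain carbon, two bonds along the chain from two carbonyl carbons, gives a 41-fold higher number from compound 1 to compound 4 (1.62 log units; beyond the scatter) in this assay. This position, which the earlier step on the amide-type nitrogen did not touch, therefore has a large bearing on the half-life, and the phenyl is not required for a long one. Nothing available accounts for the size of this step.

Going by these compounds, whether a longer chain or an amine at this carbon would keep the higher number remains open. So does whether methyl on the amide-type nitrogen would behave the same way on the core of compound 4.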